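This account rests on a few compounds, and the source may have more. Where it says the series, first, only, none or still open, it means among the compounds named here.

Working notes on a pair of cores carrying the same thioether-linked side chains.

Compound 1 `Cn1nc(-c2nnc(SCc3ccc(C(F)(F)F)cc3)o2)cc1-c1ccc(C(F)(F)F)cc1`, in a functional assay on A549 cells (Homo sapiens) for cytotoxicity, read by MTT assay, with a stated time of 24 h (a higher number here means a weaker inhibitor, a lower number a stronger inhibitor), gives 29200 nM. Compound 2 `Cn1nc(-c2nnc(SCCc3ccc(F)cc3)o2)cc1-c1ccc(C(F)(F)F)cc1` differs from it by 4-fluorobenzyl in place of 4-(trifluoromethyl)phenyl on a saturated chain carbon bound to a sulfur, and in this assay compound 2 gives 39000 nM; the step of a 1.3-fold higher number from compound 1 to compound 2 (0.13 log units; within the scatter) is small. Compound 3 `Cn1nc(-c2ccc(C(F)(F)F)cc2)cc1-c1nnc(SCc2ccc(C(F)(F)F)cc2)o1` has the same atoms as compound 1 joined differently; the difference between the two cores is not broken down here, and in this assay compound 3 gives 39800 nM, close to both compound 1 and compound 2. Compound 4 `Cn1nc(-c2ccc(C(F)(F)F)cc2)cc1-c1nnc(SCCc2ccc(F)cc2)o1` stands to compound 3 as compound 2 stands to compound 1, by 4-fluorobenzyl in place of 4-(trifluoromethyl)phenyl on a saturated chain carbon bound to a sulfur; the two "place" descriptions are the same word for word, so this is the same change applied to the second core. Among the measured compounds shown here, with only the one measured instance of this change, the expectation rests on it alone. For compound 4 the step is expected to read a 1.3-fold higher number from compound 3 to compound 4 (0.10 log units; within the scatter), much like the step from compound 1 to compound 2, because a 1.3-fold higher number from compound 1 to compound 2 (0.13 log units; within the scatter) stayed within the usual scatter. Compound 4 is therefore estimated at 50000 nM in this assay, with a likely range from 20000 nM to 120000 nM.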

Compound 4, half-maximal inhibitory concentration: 84200 nM
The estimate for compound 4 lay 1.7-fold (0.23 log units) below the measured number; measured number inside the range.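

In this assay, 4-fluorobenzyl in place of 4-(trifluoromethyl)phenyl on a saturated chain carbon bound to a sulfur gives a 2.1-fold higher number from compound 3 to compound 4 (0.33 log units; beyond the scatter) on the second core. Both instances of the change run in the same direction, and the gap between them is no larger than repeated measurements would allow, so the change carries over between these two cores as far as two steps can tell: the same change on two cores in this assay, a 1.3-fold higher number (0.13 log units; within the scatter) from compound 1 to compound 2 and a 2.1-fold higher number (0.33 log units; beyond the scatter) from compound 3 to compound 4, 1.6-fold (0.20 log units) apart, within the scatter of two such steps

This does not show that the second core responds more strongly, even though only its step lies beyond the scatter, and one pair of side chains on two cores says nothing about other side chains or other cores.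

Still open, as far as these compounds go, is whether a side chain ending in an amine or a carboxylic acid, or a longer chain on the sulfur, would give similar steps on both cores. Also open, from the compounds shown here alone, is whether the agreement between the two steps holds outside this single cytotoxicity read-out.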